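Thiophene series: halogen versus aryl at the sulfur-adjacent position

This account rests on a few compounds, and the source may have more. Where it says the series, first, only, none or still open, it means among the compounds named here.

Measured so far:
compound 1, `Nc1sc(Br)c(-c2cccc(C(F)(F)F)c2)c1C(=O)c1ccccc1`: 47.5%
compound 2, `Nc1sc(-c2ccc(Cl)cc2)c(-c2cccc(C(F)(F)F)c2)c1C(=O)c1ccccc1`: 59.1%

In an assay on CHO-K1 cells for displacement of a labelled ligand from adenosine receptor A1 (Homo sapiens), tested at 10 uM (on this read-out lower numbers stand for less inhibition and higher numbers for more inhibition at the one concentration tested (going by the name of the read-out)), compound 2 gives 59.1%, the higher of the two numbers in hand; compound 1 gives 47.5%, and the step of a number 11.6 percentage points higher from compound 1 to compound 2 (beyond the scatter) came with 4-chlorophenyl in place of bromo on an aromatic carbon.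

Compound 3, `Nc1sc(Cl)c(-c2cccc(C(F)(F)F)c2)c1C(=O)c1ccccc1`, has not been measured. It differs from compound 2 by chloro in place of 4-chlorophenyl on an aromatic carbon.

Within the data shown here, the only measured step that bears on this change is a number 11.6 percentage points higher from compound 1 to compound 2 (beyond the scatter), and the change to compound 3 runs the other way: the aryl group leaves and a single halogen returns. Compound 3 carries chloro where compound 1 carries bromo, so compound 3 is expected to sit near compound 1 because of 47.5%. The expected step is a number 14.1 percentage points lower from compound 2 to compound 3 (beyond the scatter), a modest drop beyond the scatter. Compound 3 is therefore estimated at 45%, with a range of 30% to 60%.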

Compound 3, a percentage reported as inhibition, at one concentration (the size of the read-out at that concentration, not a potency): 87.1%
Estimate against measurement, compound 3: 42.1 percentage points below; the whole stated range lies below it.
By their numbers in this assay, from the lowest: compound 1; then compound 2; then compound 3.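

At this position, next to the ring sulfur, the identity of the halogen matters in this assay: chloro in place of bromo gives a number 39.6 percentage points higher from compound 1 to compound 3 (beyond the scatter), so the two halogens cannot be treated as interchangeable. Chloro in place of 4-chlorophenyl gives a number 28 percentage points higher from compound 2 to compound 3 (beyond the scatter), which places the aryl compound between the two halogen compounds and shows that the larger group does not give the highest number among these three. Nothing in hand explains why chloro and bromo differ here.

Going by these compounds, it remains open where fluoro, iodo, a methyl group or an amine would fall at this position relative to chloro and bromo. With one tested concentration, these numbers also leave the potency of all three compounds undetermined.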